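Removing the Chloro Group from Compound 3

The source may report more compounds than this note shows. Statements on the series, on what has been measured and on what is new or still open speak of the compounds shown alone.

The measured compounds:
compound 1 `Clc1ccc(NC2=NCCC3(CCCCC3)S2)cc1` gives 27.8 10^-6 cm/s in a physicochemical assay for permeability; on this read-out higher numbers stand for higher permeability and lower numbers for lower permeability
compound 2 `CC(=O)c1ccc(NC2=NCCC3(CCCCC3)S2)cc1` gives 2.55 10^-6 cm/s in this assay
compound 3 `Cc1ccc(NC2=NCCC3(CCCCC3)S2)cc1Cl` gives 23.9 10^-6 cm/s in this assay

Compound 3 stands second highest of the three numbers. Its nearest neighbour is compound 1, whose number lies within the scatter of that of compound 3; its furthest is compound 2, whose number is beyond the scatter below it. Among the compounds with values here, the single one-place step seen so far is an 11-fold lower number from compound 1 to compound 2 (1.04 log units; beyond the scatter).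

Compound 4 `Cc1ccc(NC2=NCCC3(CCCCC3)S2)cc1` differs from compound 3 in one place: hydrogen in place of chloro on an aromatic carbon

Within the data shown here, no measured step involves a chloro group replaced by hydrogen, so the only step at hand, an 11-fold lower number from compound 1 to compound 2 (1.04 log units; beyond the scatter), concerns a different change and bears on this one only loosely. Compound 3 and compound 1 sit close together, and nothing here points to a large shift; the step from compound 3 to compound 4 is therefore expected to be a 1.1-fold lower number from compound 3 to compound 4 (0.04 log units; within the scatter), none beyond the scatter. In this assay compound 4 is estimated at 22 10^-6 cm/s, with a range from 10 10^-6 cm/s to 45 10^-6 cm/s.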

Compound 4, apparent permeability: 5.67 10^-6 cm/s
Estimate against measurement, compound 4: 3.9-fold (0.59 log units) above; the whole stated range lies above it.
By their numbers in this assay, from the lowest: compound 2; then compound 4; then compounds 3 and 1 (each within the scatter of the next).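

In this assay the chloro group on the aromatic carbon ortho to a methyl group proves far from silent: hydrogen in its place gives a 4.2-fold lower number from compound 3 to compound 4 (0.62 log units; beyond the scatter) and the methyl group alone does not hold the number. Methyl in place of chloro gives a 4.9-fold lower number from compound 1 to compound 4 (0.69 log units; beyond the scatter) while methyl in place of acetyl gives a 2.2-fold higher number from compound 2 to compound 4 (0.35 log units; beyond the scatter) so compound 4 stands clear of compound 2 yet well short of the chlorinated pair. Nothing at hand accounts for these steps. Going by these compounds, whether a fluoro, a methoxy or an amine on this carbon would match chloro stays open.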